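The compounds below may be only part of what the source reports. "The series", "measured", "known", "first", "only" and "open" are said of these compounds alone.

In an ADME assay on microsomes from liver (Homo sapiens) for metabolic stability (on this read-out higher numbers stand for fast clearance and lower numbers for slow clearance), compound 1 `Cc1ccc([C@H](C)NC(=O)Cn2nnc3ccccc3c2=O)cc1` gives < 9.9 mL/min/kg and this is a limit, not a number (the limit of < 9.9 mL/min/kg in this assay, at which 1 of the 3 values shown sits). Compound 2 `Cc1ccc([C@H](C)NC(=O)C(C)n2nnc3ccccc3c2=O)cc1` gives 13 mL/min/kg and compound 3 `Cc1ccc([C@@H](NC(=O)Cn2nnc3ccccc3c2=O)C(C)C)cc1` gives 34 mL/min/kg in this assay as well. The measured steps are an at least 1.3-fold higher number from compound 1 to compound 2 (0.11 log units; that floor lies within the scatter) and an at least 3.4-fold higher number from compound 1 to compound 3 (0.53 log units; beyond the scatter), and neither touches the 4-methylphenyl, so they bear only loosely on what follows. Compound 4 `C[C@H](NC(=O)Cn1nnc2ccccc2c1=O)c1ccn(C)n1` carries 1-methyl-1H-pyrazol-3-yl in place of 4-methylphenyl on a saturated chain carbon bound to an amide-type nitrogen and a saturated chain carbon, with 1-methyl-1H-pyrazol-3-yl in place of 4-methylphenyl. No step beyond the scatter is therefore expected in this assay for this change. For compound 4 the expected step is a step that the limit leaves unreadable from compound 1 to compound 4 in size. Compound 4 is estimated at 9.5 mL/min/kg within an expected range of 6 mL/min/kg to 16 mL/min/kg in this measurement.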

Compound 4, clearance: 12 mL/min/kg
Compound 4: the middle estimate sits 1.3-fold (0.10 log units) below what was measured, and the stated range covers the measured number.
By their numbers in this assay, from the lowest: compounds 4 and 2 (each within the scatter of the next); then compound 3. At a limit, below all of these: compound 1.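

In this assay, the step from 4-methylphenyl to 1-methyl-1H-pyrazol-3-yl is the first shown to change this aromatic group, and it reads as an at least 1.2-fold higher number from compound 1 to compound 4 (0.08 log units; that floor lies within the scatter). Compound 1 stands at a limit, not a number: the limit of < 9.9 mL/min/kg in this assay, at which 1 of the 4 values shown sits. Only a floor can therefore be read, and that floor shows no change beyond the scatter for a five-membered aromatic ring with 2 hetero atoms in this place.

As far as these compounds go, the true size of the step stays open. So does how a carboxylic acid or an amine in place of 4-methylphenyl would read in this assay.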